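This account rests on a few compounds, and the source may have more. Where it says the series, first, only, none or still open, it means among the compounds named here.

Measured compounds:
- compound 1 `C[C@H](Nc1nc(N)nc(N)c1C#N)c1cc2ccc(F)cn2c(=O)c1-c1ccccc1`: 1.8 nM
- compound 2 `C[C@H](Nc1nc(N)nc(N)c1C#N)c1c(-c2ccccc2)c(=O)n2cc(F)ccc2c1-c1ccccc1`: 160 nM

Compound 2 holds the higher of the two numbers in a functional assay on SU-DHL-6 cells (Homo sapiens) for inhibition, read by CellTiter-Glo and ATP content, with a stated time of 96 h; a lower number here means a stronger inhibitor, a higher number a weaker inhibitor; its nearest neighbour is compound 1, and the step of an 89-fold higher number from compound 1 to compound 2 (1.95 log units; beyond the scatter) is large. Compound 3 `C[C@H](Nc1nc(N)nc(N)c1C#N)c1c(-c2ccccc2)c(=O)n2cc(F)ccc2c1-c1ccc(F)cc1` has not yet been measured in this assay. It differs from compound 2 by fluoro in place of hydrogen on an aromatic carbon, set on a six-membered aromatic ring of carbon only, para to a large group; cut one bond further out the change reads phenyl to 4-fluorophenyl.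

For the measured compounds named here, no measured step bears directly on this change. Going by the values given here, the only step available, an 89-fold higher number from compound 1 to compound 2 (1.95 log units; beyond the scatter), concerns a phenyl entering in place of hydrogen, a much larger change than a single fluorine. With nothing in the data pointing either way, the step of a 1.1-fold lower number from compound 2 to compound 3 (0.03 log units; within the scatter) is expected to stay within the scatter. Compound 3 is therefore estimated at 150 nM, with a range from 55 nM to 420 nM.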

Compound 3, half-maximal inhibitory concentration: < 0.1 nM
Compound 3: a limit, no number (the forecaster's own chance of this, stated with the estimate: 2%); middle value at least 1500-fold (3.17 log units) away from the limit.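

In this assay compound 3 gives < 0.1 nM, which is a limit of the assay and not a number. The earlier compounds shown here showed only that a phenyl at this aromatic carbon of the core costs heavily, whereas a single fluoro para to a large group, turning phenyl into 4-fluorophenyl, gives an at least 1600-fold lower number from compound 2 to compound 3 (3.20 log units; beyond the scatter), so the outcome here hangs on that one atom. Measured against hydrogen at the same carbon, 4-fluorophenyl gives an at least 18-fold lower number from compound 1 to compound 3 (1.25 log units; beyond the scatter), opposite in direction to the phenyl step, an 89-fold higher number from compound 1 to compound 2 (1.95 log units; beyond the scatter).

As far as these compounds go, whether this gain is peculiar to fluoro, or would also appear with chloro, methoxy or an amine in its place on the ring, remains open. The full size of both new steps also remains open, as neither has a number at its lower end: the limit of < 0.1 nM in this assay, at which 1 of the 3 values shown sits.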